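A few compounds are considered here, and "the series" means these few. Any claim that something is new, unique, unknown or untested is made for them only; others in the source may bear on it.

Measured compounds in a functional assay on SF-295 cells (Homo sapiens) for inhibition, read by sulforhodamine B assay, with a stated time of 48 h; on this read-out lower numbers stand for stronger inhibition of growth and higher numbers for weaker inhibition of growth: compound 1, `N#C/C(=C\N1CCN(C(=O)c2ccco2)C1=S)C(=O)Nc1ccc(Cl)cc1`, gives 20200 nM; compound 2, `N#C/C(=C\N1CCN(C(=O)c2ccco2)C1=S)C(N)=O`, gives 32100 nM.

Among the measured compounds shown here, compound 2 stands at the higher of the two numbers, though its only neighbour, compound 1, sits close: the step of a 1.6-fold higher number from compound 1 to compound 2 (0.20 log units; within the scatter) is within the scatter, so the two compounds cannot be ordered against each other.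

Compound 3, `N#C/C(=C\N1CCN(C(=O)c2ccco2)C1=S)C(=O)c1ccccc1`, has not yet been measured in this assay. It differs from compound 2 by phenyl in place of amino on a carbonyl carbon. For the measured compounds named here, only one measured step bears on this change, and it only loosely: the step of a 1.6-fold higher number from compound 1 to compound 2 (0.20 log units; within the scatter), in which an aromatic ring was removed from the amide-type nitrogen rather than put on the carbonyl carbon, and it stayed within the scatter. Going by the values given here, with one such step, and no measured pair that replaces amino by phenyl, there is no firm ground for expecting a move beyond the scatter in either direction.

The step from compound 2 to compound 3 is therefore expected to be small, a 1.6-fold lower number from compound 2 to compound 3 (0.21 log units; within the scatter). Compound 3 is estimated at 20000 nM, with a likely range from 6000 nM to 65000 nM.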

Compound 3, concentration for 50% growth inhibition: 43600 nM
Compound 3: the middle estimate sits 2.2-fold (0.34 log units) below what was measured; the range from low to high includes it.
By their numbers in this assay, from the lowest: compounds 1, 2 and 3 (each within the scatter of the next, the first and the last beyond it).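

On the carbonyl carbon that carries amino in compound 2, phenyl can stand in this assay with no readable shift, the step being a 1.4-fold higher number from compound 2 to compound 3 (0.13 log units; within the scatter) and leaving carbamoyl and benzoyl at this place unordered. The same place does yield the first gap beyond the scatter in this series, though a modest one, at a 2.2-fold higher number from compound 1 to compound 3 (0.33 log units; beyond the scatter) when phenyl takes the place of (4-chlorophenyl)amino, and this goes with weaker inhibition of growth, while compound 2 cannot be ordered against either compound 1 or compound 3. Nothing given here accounts for this gap.

The compounds shown do not separate the contribution of the chlorine in compound 1 from that of its amide hydrogen or its aromatic ring, since no compound here carries an unsubstituted phenylamino group or a 4-chlorophenyl directly on the carbonyl carbon. From the compounds shown here alone, it also stays open how this place would respond to a methyl group, a hydroxyl group or a piperidine in place of these groups, and whether any change here could bring the numbers far below those of the shared core seen so far.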